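The source may hold more compounds than are shown below. What is called first, only, known or untested is meant among the compounds shown, and "the series" means these compounds.

Working notes on a set of amino acid solubility analogues.

Compound 1 `CCCN(Cc1ccc(OCCN2C(=O)CCC2=O)c(C)c1)C(CC(=O)O)c1ccc(Cl)cc1` and compound 2 `Cc1cc(CN(CC2CC2)C(CC(=O)O)c2ccc(Cl)cc2)ccc1OCCN1C(=O)CCC1=O` share one core; compound 3 `CCCN(Cc1ccc(OCCn2c(=O)ccn(C)c2=O)c(OC)c1)C(CC(=O)O)c1ccc(Cl)cc1` and compound 4 `COc1cc(CN(CC2CC2)C(CC(=O)O)c2ccc(Cl)cc2)ccc1OCCn1c(=O)ccn(C)c1=O` share another, and the difference between the two cores is not broken down here. In a physicochemical assay for solubility, at pH 1.1 (a higher number here means a more soluble compound, a lower number a less soluble compound), compound 1 gives 3000000 nM. Compound 2 gives 3000000 nM in this assay, and the step of no change at the digits printed from compound 1 to compound 2 (within the scatter) comes from cyclopropyl in place of ethyl on a saturated chain carbon bound to an amine nitrogen. Compound 3 gives 3000000 nM in this assay, level with compounds 1 and 2 at the digits shown.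

Compound 4 is still to be measured in this assay. Its difference from compound 3 is cyclopropyl in place of ethyl on a saturated chain carbon bound to an amine nitrogen, which is the same change as that from compound 1 to compound 2, since both place lines read alike word for word. Because the earlier step of no change at the digits printed from compound 1 to compound 2 (within the scatter) stayed within the scatter, the expectation for compound 4 is a step of no change at the digits printed from compound 3 to compound 4 (within the scatter), again flat. Compound 4 is therefore estimated at 3000000 nM in this assay, with an expected range from 1500000 nM to 6000000 nM. The measurement will show whether this holds.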

Compound 4, solubility: 3000000 nM
The estimate for compound 4 equals the measured number at the digits printed; the measured number falls inside the stated range.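

In this assay, replacing ethyl with cyclopropyl on a saturated chain carbon bound to an amine nitrogen gives no change at the digits printed from compound 3 to compound 4 (within the scatter), matching the step in the other core, no change at the digits printed from compound 1 to compound 2 (within the scatter). Within the data shown here, the change therefore reads the same in these two cores, but this rests on only two pairs, both flat, so it shows agreement between two steps that lie within the scatter, not that a step of visible size would carry from one core to the other, nor that the same would hold in any further core. Nothing available bears on why either step is flat.

Still open, on these data alone, is how a longer chain such as butyl, or a chain ending in a primary amine or a hydroxyl group, would read at this place in either core. Also open, as far as these compounds go, is whether any such group would give a step beyond the scatter in this assay, and whether that step would match between the two cores.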